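A few compounds are considered here, and "the series" means these few. Any claim that something is new, unique, unknown or untested is made for them only; others in the source may bear on it.

Measured compounds:
compound 1, `CCN(Cc1cc[nH]n1)C(=O)COc1ccc(C)cc1` — "not active" (no number reported)
compound 2, `CCN(Cc1cc[nH]c1)C(=O)COc1ccc(C)cc1` — 21800 nM

Going by the values given here, in an assay on HEK293 cells for agonist activity at transient receptor potential cation channel subfamily M member 8 (Homo sapiens), read by fluorescence and calcium flux, with a stated time of 15 min (on this read-out higher numbers stand for an effect only at larger amounts of compound and lower numbers for an effect already at smaller amounts), compound 2 is the only compound with a number; compound 1 gives "not active" (no number reported) and so offers no value to set beside it. Compound 2 thus stands alone, and its value lies at large amounts of compound.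

Compound 3, `CCN(Cc1cn[nH]c1)C(=O)COc1ccc(C)cc1`, is not yet measured. It differs from compound 2 in one place: 1H-pyrazol-4-yl in place of 1H-pyrrol-3-yl on a saturated chain carbon bound to an amide-type nitrogen. Among the compounds with values here, no pair of measured compounds shows this change, so its size is not known from the numbers at hand.

The account expects a small step from compound 2 to compound 3, toward larger amounts or none beyond the scatter, estimated as a 1.4-fold higher number from compound 2 to compound 3 (0.14 log units; within the scatter), in part because compound 1 gives "not active" (no number reported). Compound 3 is therefore estimated at 30000 nM, with a range from 10000 nM to 100000 nM.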

Compound 3, half-maximal effective concentration: "active" (no number reported)
Compound 3: no number reported; the estimate stays without a comparison.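

In this assay, going by these compounds alone, compound 3 gives "active" (no number reported) and so no step from compound 2 to compound 3 can be read. No evidence at hand bears on this result. The compounds shown leave open how large the change from 1H-pyrrol-3-yl to 1H-pyrazol-4-yl is.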